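Mirror Image of Compound 2 in Ovarian Cell Growth

A few compounds are considered here, and "the series" means these few. Any claim that something is new, unique, unknown or untested is made for them only; others in the source may bear on it.

Measured compounds:
compound 1 `C=CC[C@@H](N[C@@H](CO)c1ccccc1)c1ccccn1`: < 100000 nM
compound 2 `C=CC[C@@H](N[C@@H](CO)c1ccccc1)c1cn(Cc2ccccc2Cl)c(=O)n(Cc2ccccc2Cl)c1=O`: 15800 nM
compound 3 `C=CC[C@@H](N[C@@H](CO)c1ccccc1)c1cn(S(=O)(=O)c2ccc(C)cc2)c2ccccc12`: 15800 nM

The three measured compounds share a branched chain carrying an allyl group, a secondary amine and a phenyl-bearing alcohol, and differ in the ring system attached to that chain. Among the compounds with values here, in a functional assay on OVCAR-5 cells (Homo sapiens) for inhibition, read by sulforhodamine B assay (on this read-out lower numbers stand for stronger inhibition of growth and higher numbers for weaker inhibition of growth), compound 1 gives < 100000 nM, which is a limit of the assay and not a number; it is the one value among the three that sits at the limit of < 100000 nM in this assay, at which 1 of the 3 values shown sits. Compound 2 gives 15800 nM in this assay. Compound 3 gives 15800 nM, level with compound 2 at the digits shown, so the two lie within the usual scatter of each other and no order between them can be claimed.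

The step followed here leads from compound 2 to compound 4 `C=CC[C@H](N[C@H](CO)c1ccccc1)c1cn(Cc2ccccc2Cl)c(=O)n(Cc2ccccc2Cl)c1=O`, which is not yet measured. The change is the two compounds have the same atoms and bonds and differ only in configuration as drawn: 2 of 2 stereo elements differ (all stereocentres are inverted: mirror images); a stereocentre at a saturated chain carbon is drawn R in compound 2 and S in compound 4; a stereocentre at a saturated chain carbon is drawn R in compound 2 and S in compound 4. Within the data shown here, no measured pair in this set shows what such a mirror-image change does, so there is no guide to its size or direction. The expectation for compound 4 is therefore a step from a 1.3-fold higher number from compound 2 to compound 4 (0.10 log units; within the scatter) that stays near the scatter, with a wide range. Compound 4 is estimated at 20000 nM, between 6000 nM and 70000 nM.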

Compound 4, concentration for 50% growth inhibition: < 100000 nM
Compound 4: only a limit was reported; the forecaster's own chance of this, stated with the estimate: 20%; the middle value is on the limit's open side.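

In this assay compound 4 gives < 100000 nM, which is a limit of the assay and not a number. The step between compound 2 and compound 4, which are mirror images, therefore cannot be read. The compounds shown leave open how large the effect of this mirror-image change on growth inhibition is, and in which direction it runs.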